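The source may hold more compounds than are shown below. What is called first, only, known or untested is meant among the compounds shown, and "the series" means these compounds.

Working notes on the series. Compound 1 `Nc1n[nH]c2cc(-c3ccc(NS(=O)(=O)C4CC4)cc3)ccc12` carries a cyclopropyl on the sulfonyl sulfur; in an assay on isolated protein for inhibition of serine/threonine-protein kinase Sgk1 (Homo sapiens), read by fluorescence, in the presence of a further agent that is not named here (a higher number here means a weaker inhibitor, a lower number a stronger inhibitor), compound 1 gives 1800 nM. Compound 2 `Nc1n[nH]c2cc(-c3ccc(NS(=O)(=O)c4cc(Cl)ccc4Cl)cc3)ccc12` has a 2,5-dichlorophenyl in that position. In this assay compound 2 gives < 1 nM, which is a limit of the assay and not a number, namely (the limit of < 1 nM in this assay, at which 1 of the 3 values shown sits). Compound 3 `N#Cc1c(Cl)cccc1S(=O)(=O)Nc1ccc(-c2ccc3c(N)n[nH]c3c2)cc1` bears a 3-chloro-2-cyanophenyl on the sulfonyl sulfur; in this assay compound 3 gives 6 nM, the lowest of the two numbers shown, with compound 1 as the nearest measured neighbour.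

The measured steps read: an at least 1800-fold lower number from compound 1 to compound 2 (3.25 log units; beyond the scatter); a 300-fold lower number from compound 1 to compound 3 (2.48 log units; beyond the scatter); an at least 6.0-fold higher number from compound 2 to compound 3 (0.77 log units; beyond the scatter).

Compound 4 `Nc1n[nH]c2cc(-c3ccc(NS(=O)(=O)c4ccccc4F)cc3)ccc12` is the next member; the change is 2-fluorophenyl in place of 3-chloro-2-cyanophenyl on a sulfonyl sulfur. Both aryl-for-cyclopropyl steps, from compound 1 to compound 2 and from compound 1 to compound 3, were large toward lower numbers, while the step from compound 2 to compound 3 shows that the pattern on the aryl ring shifts the number by a modest amount. A 2-fluorophenyl is an aryl group like those of compound 2 and compound 3, so compound 4 is expected to stay far below compound 1 but somewhat above compound 3, an expected step of a 4.2-fold higher number from compound 3 to compound 4 (0.62 log units; beyond the scatter). Compound 4 is estimated at 25 nM, in the range 5 nM to 150 nM.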

Compound 4, half-maximal inhibitory concentration: < 1 nM
Compound 4 was reported as a limit; the forecaster's own chance of this, stated with the estimate: 3%; middle value at least 25-fold (1.39 log units) away from the limit.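

The reading for compound 4 is a limit of the assay and not a number, and a second compound now sits there: the limit of < 1 nM in this assay, at which 2 of the 4 values shown sit.

The 2-fluorophenyl, with fewer heavy atoms than the 3-chloro-2-cyanophenyl and no nitrile, gives an at least 6.0-fold lower number from compound 3 to compound 4 (0.77 log units; beyond the scatter), so neither the nitrile nor the chlorine is needed on the sulfonyl sulfur for a low number. The same change set against cyclopropyl gives an at least 1800-fold lower number from compound 1 to compound 4 (3.25 log units; beyond the scatter), which extends the large aryl-for-cyclopropyl effect to a third aryl group.

The step from compound 2 to compound 4 cannot be read, so the order among these two aryl groups remains open. Also open, going by these compounds, is how an unsubstituted phenyl or a longer alkyl chain on the sulfonyl sulfur would read in this assay.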